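Methoxy in place of fluoro, starting from a limit

This account rests on a few compounds, and the source may have more. Where it says the series, first, only, none or still open, it means among the compounds named here.

Compound 1 (`CCOC(=O)c1c(-c2cccc(F)c2)[nH]c2cc(OC)ccc2c1=O`) gives > 100000 nM in a physicochemical assay for solubility, in phosphate buffer, at pH 7.4 (on this read-out lower numbers stand for lower solubility and higher numbers for higher solubility), which is a limit of the assay and not a number. Compound 2 (`CCOC(=O)c1c(-c2cccc(F)c2)[nH]c2cccc(OC)c2c1=O`) gives > 100000 nM, also a limit. Going by the values given here, these two compounds sit at the limit of > 100000 nM in this assay, at which 2 of the 2 values shown sit, and no measured step is available. Compound 3 (`CCOC(=O)c1c(-c2cccc(OC)c2)[nH]c2cc(OC)ccc2c1=O`) carries methoxy in place of fluoro on an aromatic carbon, meta to a large group: methoxy in place of fluoro on an aromatic carbon. In this assay, the expected size of a number no higher from compound 1 to compound 3 (the limit leaves the size open) is nothing beyond the scatter, in either direction. Compound 3 is estimated at 100000 nM, with an expected range of 40000 nM to 200000 nM.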

Compound 3, solubility: > 100000 nM
Compound 3 ended at the assay's limit; the forecaster's own chance of this, stated with the estimate: 70%; the middle value sits exactly at the limit.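

No step can be read from compound 1 to compound 3, because both values are limits of the assay: the limit of > 100000 nM in this assay, at which 3 of the 3 values shown sit. The compounds shown leave open whether methoxy in place of fluoro on an aromatic carbon changes the read-out in this assay at all.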